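Swapping a para substituent on the aryl ketone

This account rests on a few compounds, and the source may have more. Where it says the series, first, only, none or still open, it means among the compounds named here.

Of the compounds shown here, three sharing one core have been measured in a functional assay on PC-3 cells (Homo sapiens) for cytotoxicity, read by MTT assay, with a stated time of 48 h; a higher number here means a weaker inhibitor, a lower number a stronger inhibitor. Compound 1 `COc1cc(C(=O)C2Sc3nnc(-c4cc(OC)c(OC)c(OC)c4)n3NC2c2ccco2)cc(OC)c1OC` gives 52200 nM. Compound 2 `COc1cc(-c2nnc3n2NC(c2ccco2)C(C(=O)c2ccc(Br)cc2)S3)cc(OC)c1OC` gives 36400 nM, and compound 3 `COc1cc(-c2nnc3n2NC(c2ccco2)C(C(=O)c2ccc(F)cc2)S3)cc(OC)c1OC` gives 27700 nM, the lowest of the three numbers, although every step reaching it stays within the scatter: a 1.4-fold lower number from compound 1 to compound 2 (0.16 log units; within the scatter), a 1.9-fold lower number from compound 1 to compound 3 (0.28 log units; within the scatter) and a 1.3-fold lower number from compound 2 to compound 3 (0.12 log units; within the scatter). Compound 4 `COc1cc(-c2nnc3n2NC(c2ccco2)C(C(=O)c2ccc(C)cc2)S3)cc(OC)c1OC` differs from compound 3 by methyl in place of fluoro on an aromatic carbon. Of the measured steps, a 1.3-fold lower number from compound 2 to compound 3 (0.12 log units; within the scatter) bears most directly on this change, the earlier exchange sitting on the same aromatic carbon, and the ring exchanges a 1.4-fold lower number from compound 1 to compound 2 (0.16 log units; within the scatter) and a 1.9-fold lower number from compound 1 to compound 3 (0.28 log units; within the scatter) were likewise within the scatter. The expected step is a 1.1-fold higher number from compound 3 to compound 4 (0.03 log units; within the scatter), meaning nothing beyond the scatter. Compound 4 is estimated at 30000 nM, with a range from 13000 nM to 70000 nM.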

Compound 4, half-maximal inhibitory concentration: 7500 nM
Compound 4: the middle estimate sits 4.0-fold (0.60 log units) above what was measured, outside the stated range (below it).
By their numbers in this assay, from the lowest: compound 4; then compounds 3, 2 and 1 (each within the scatter of the next).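

At this aromatic carbon, methyl separates from both halogens in this assay, with a 3.7-fold lower number from compound 3 to compound 4 (0.57 log units; beyond the scatter) and a 4.9-fold lower number from compound 2 to compound 4 (0.69 log units; beyond the scatter), whereas fluoro and bromo stayed within the scatter of each other. The step of a 7.0-fold lower number from compound 1 to compound 4 (0.84 log units; beyond the scatter) also shows 4-methylphenyl separating from 3,4,5-trimethoxyphenyl on the carbonyl, which neither halogen-bearing ring did. Nothing measured here accounts for this difference. On these data alone, whether the lower number is particular to methyl remains open, since a longer chain such as ethyl, or an amine, on the same carbon could follow it or not.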